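The source may report more compounds than this note shows. Statements on the series, on what has been measured and on what is new or still open speak of the compounds shown alone.

Measured compounds and their values:

Compound 1, `COc1ccc(C(=O)c2ccc3c(c2)C(n2ccccc2=O)=CC(C)(C)O3)cc1`: 6.15
Compound 2, `CC1(C)C=C(n2ccccc2=O)c2cc(C(=O)c3cccs3)ccc2O1`: 6.4
Compound 3, `CC1(C)C=C(n2ccccc2=O)c2cc(C(=O)c3ccco3)ccc2O1`: 6.49

In a functional assay (aorta) with Rattus norvegicus as the target (on this read-out lower numbers stand for lower potency and higher numbers for higher potency (the scale is a negative logarithm)), compound 1 gives 6.15 and stands lowest of the three numbers, though its distance to compound 2 is within the scatter and only its distance to compound 3 goes beyond it. Compound 4, `CC1(C)C=C(n2ccccc2=O)c2cc(C(=O)c3ccccc3F)ccc2O1`, has not yet been measured. It differs from compound 1 in one place: 2-fluorophenyl in place of 4-methoxyphenyl on a carbonyl carbon.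

Two of the measured steps bear on this change, since each also swaps the group on the carbonyl carbon of compound 1 for another aromatic ring: a number 0.25 log units higher from compound 1 to compound 2 (within the scatter) and a number 0.34 log units higher from compound 1 to compound 3 (beyond the scatter). Both were small and pointed upward, and the step between compound 2 and compound 3, a number 0.09 log units higher from compound 2 to compound 3 (within the scatter), shows that the replacement rings gave much the same number. Within the data shown here, no measured step shows 2-fluorophenyl itself, so the size of the step is uncertain. The step expected from compound 1 to compound 4 in this assay is therefore small, a number 0.15 log units higher from compound 1 to compound 4 (within the scatter), and may well lie within the scatter. For compound 4 the estimate in this assay is 6.3, with a range from 5.8 to 6.8.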

Compound 4, logarithm of the reciprocal of the active concentration, log(1/C): 7.08
Compound 4: middle estimate off by 0.78 log units, on the low side; the whole stated range lies below it.
By their numbers in this assay, from the lowest: compounds 1, 2 and 3 (each within the scatter of the next, the first and the last beyond it); then compound 4.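

In this assay, the group on the carbonyl carbon proves able to move the number well beyond the small differences seen so far: placing 2-fluorophenyl there gives a number 0.93 log units higher from compound 1 to compound 4 (beyond the scatter). The same group also gives a number 0.68 log units higher from compound 2 to compound 4 (beyond the scatter) and a number 0.59 log units higher from compound 3 to compound 4 (beyond the scatter), so compound 4 stands clear of all three earlier compounds. Compound 1 and compound 4 both carry a six-membered aromatic ring of carbon only at this place, so the presence of such a ring does not by itself fix the number, and nothing measured here explains the rise.

The compounds shown include no plain phenyl, 4-fluorophenyl or 2-methoxyphenyl on the carbonyl carbon, so it remains open whether the gain follows the fluorine, its place on the ring, or the loss of 4-methoxy. Going by these compounds, whether 2-chlorophenyl would give a similar number is also open.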